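Removing the ring chlorine from compound 3

This account rests on a few compounds, and the source may have more. Where it says the series, first, only, none or still open, it means among the compounds named here.

Compound 3 `Cc1ccc(Nc2nc(C)c(C(=O)/C=C/c3ccccc3Cl)s2)cc1` reaches only a limit in a functional assay on NCI-H460 cells (Homo sapiens) for cytotoxicity, read by MTT assay; a lower number here means a stronger inhibitor, a higher number a weaker inhibitor: in this assay compound 3 gives > 25000 nM, a limit and not a number. Compound 4 `Cc1ccc(Nc2nc(C)c(C(=O)/C=C/c3ccccc3)s2)cc1` differs from it by hydrogen in place of chloro on an aromatic carbon. Among the measured compounds shown here, no measured step touches this ring. Compound 1 `Cc1nc(Nc2cccc(Cl)c2)sc1C(=O)/C=C/c1ccccc1` also gives only a limit in this assay, > 25000 nM. Compound 2 `Cc1nc(Nc2ccc(Cl)c(Cl)c2)sc1C(=O)/C=C/c1ccccc1` gives 22700 nM in this assay, and the change an at least 1.1-fold lower number from compound 1 to compound 2 (0.04 log units; that floor lies within the scatter) adds chloro on the other aromatic ring, within the scatter. Because the limit of > 25000 nM in this assay, at which 2 of the 3 values shown sit, places most of these values at the edge of measurement, weak inhibition is the common picture. Compound 4 is therefore expected near 30000 nM, likely between 8000 nM and 100000 nM, probably again as a limit. The expected step that the limit leaves unreadable from compound 3 to compound 4 is estimated to stay within the scatter.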

Compound 4, half-maximal inhibitory concentration: > 25000 nM
Compound 4 was reported as a limit (the forecaster's own chance of this, stated with the estimate: 65%); the middle value lies beyond the limit too.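

With both compound 3 and compound 4 reported only as limits, the chloro on this ring shows no readable effect, and the steps from compound 1 and compound 3 to compound 4 cannot be read. Among the compounds shown here, the only readable step is an at least 1.1-fold higher number from compound 2 to compound 4 (0.04 log units; that floor lies within the scatter), which gives a floor and not a size for replacing 3,4-dichlorophenyl with 4-methylphenyl. In this assay, the new result adds to the values sitting at the edge of measurement: the limit of > 25000 nM in this assay, at which 3 of the 4 values shown sit.

On these data alone, what the chloro does at this position stays open. So does whether an amine or a carboxylic acid on this ring would give a value inside the measurable range.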